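The source may hold more compounds than are shown below. What is called first, only, known or untested is meant among the compounds shown, and "the series" means these compounds.

Compound 1 `CC(O)(CS(=O)(=O)c1ccc(Cl)cc1)c1nc(-c2ccc([N+](=O)[O-])c(C(F)(F)F)c2)no1`: 91000 nM in a functional assay on DU-145 cells (Homo sapiens) for cytotoxicity, read by MTT assay; a higher number here means a weaker inhibitor, a lower number a stronger inhibitor
Compound 2 `CC(O)(CSc1ccc(Br)cc1)c1nc(-c2ccc([N+](=O)[O-])c(C(F)(F)F)c2)no1`: 1600 nM in this assay

Among the compounds with values here, of these two numbers, compound 2 holds the lower one, and the only step leading to it is the one from compound 1, which is a 57-fold lower number from compound 1 to compound 2 (1.75 log units; beyond the scatter). That step, however, exchanges two things at once: the sulfonyl for a sulfanyl link and the chlorine for a bromine on the ring. Within the data shown here, no measured pair separates the halogen swap from the change in the sulfur link, so the size of the halogen swap on its own is not known here.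

Compound 3 `CC(O)(CSc1ccc(Cl)cc1)c1nc(-c2ccc([N+](=O)[O-])c(C(F)(F)F)c2)no1` is the compound that would make that separation. It differs from compound 2 in one place: chloro in place of bromo on an aromatic carbon. Among the measured compounds shown here, with no step in the data isolating this exchange, the expectation rests on the general closeness of the two halogens in this position, and the expected step from compound 2 to compound 3 in this assay is a 1.3-fold higher number from compound 2 to compound 3 (0.10 log units; within the scatter), not beyond the scatter. Compound 3 is therefore expected to give about 2000 nM, within a range of 800 nM to 5000 nM.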

Compound 3, half-maximal inhibitory concentration: 1300 nM
For compound 3 the middle estimate is 1.5-fold (0.19 log units) above the measured one; the measured number falls inside the stated range.
By their numbers in this assay, from the lowest: compounds 3 and 2 (each within the scatter of the next); then compound 1.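

At the halogen site, on an aromatic carbon of a six-membered aromatic ring of carbon only, chloro and bromo cannot be told apart in this assay, where the exchange gives a 1.2-fold lower number from compound 2 to compound 3 (0.09 log units; within the scatter) and so stays within the usual scatter. With the halogen held as chloro, the sulfur link can now be read on its own, and (4-chlorophenyl)sulfanyl in place of (4-chlorophenyl)sulfonyl gives a 70-fold lower number from compound 1 to compound 3 (1.85 log units; beyond the scatter), a large step from this single exchange. Nothing in the available evidence accounts for the size of this step.

The compounds shown leave open how a sulfinyl link, an ether oxygen or a methylene group would compare with the sulfanyl and sulfonyl links at this place on the chain. They also leave open whether the tolerance seen for chloro and bromo extends to fluoro, methoxy or a plain hydrogen on the same aromatic carbon, and whether it would hold with a sulfonyl link in place of the sulfanyl link.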